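The source may report more compounds than this note shows. Statements on the series, on what has been measured and on what is new or still open speak of the compounds shown alone.

Three members of the series have been run in a functional assay on the whole organism for inhibition, with Rattus norvegicus as the target, read by paw edema; on this read-out higher numbers stand for an effect only at larger amounts of compound and lower numbers for an effect already at smaller amounts. Compound 1 `O=C(O)c1cc(-n2ccnc2)ccc1O` gives 75 mg/kg in this assay; compound 2 `O=C(O)c1cc(-c2ncco2)ccc1O` gives 100 mg/kg; compound 3 `O=C(O)c1cc(-c2ncc[nH]2)ccc1O` gives 200 mg/kg. On these three numbers compound 3 stands highest, with compound 2 nearest and compound 1 furthest. The steps among them run as follows: a 1.3-fold higher number from compound 1 to compound 2 (0.12 log units; within the scatter); a 2.7-fold higher number from compound 1 to compound 3 (0.43 log units; beyond the scatter); a 2.0-fold higher number from compound 2 to compound 3 (0.30 log units; within the scatter). For the measured compounds named here, only the step into compound 3 from compound 1 lies beyond the scatter, and that one is modest.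

Compound 4 `O=C(O)c1cc(-n2cnnc2)ccc1O` is not yet measured. It differs from compound 3 in one place: 4H-1,2,4-triazol-4-yl in place of 1H-imidazol-2-yl on an aromatic carbon. The group that enters is, like the 1H-imidazol-1-yl of compound 1, joined to the core through a ring nitrogen, whereas the 1H-imidazol-2-yl that leaves was joined through a ring carbon. The step that bears most on this change is therefore a 2.7-fold higher number from compound 1 to compound 3 (0.43 log units; beyond the scatter), now taken in reverse, with a 2.0-fold higher number from compound 2 to compound 3 (0.30 log units; within the scatter) pointing the same way though within the scatter. A step down in this assay is expected, a 2.2-fold lower number from compound 3 to compound 4 (0.35 log units; beyond the scatter), which would place compound 4 near compound 1 and compound 2 rather than near compound 3. The estimate for compound 4 is 90 mg/kg, with a range from 45 mg/kg to 180 mg/kg.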

Compound 4, dose for half-maximal effect: > 250 mg/kg
Compound 4: no number, only a limit; the forecaster's own chance of this, stated with the estimate: 5%; middle value at least 2.7-fold (0.44 log units) away from the limit.
By their numbers in this assay, from the lowest: compounds 1, 2 and 3 (each within the scatter of the next, the first and the last beyond it). At a limit, above all of these: compound 4.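

In this assay compound 4 reaches only a limit of the assay, not a number: the limit of > 250 mg/kg in this assay, at which 1 of the 4 values shown sits. Joining a five-membered aromatic ring to the core through a ring nitrogen does not by itself keep the number low at this position, meta to a carboxy group and para to a hydroxy group: both compound 1 and compound 4 are joined this way, yet the series shows an at least 3.3-fold higher number from compound 1 to compound 4 (0.52 log units; beyond the scatter), and alongside it an at least 2.5-fold higher number from compound 2 to compound 4 (0.39 log units; beyond the scatter). Against the carbon-joined 1H-imidazol-2-yl, the series shows only an at least 1.2-fold higher number from compound 3 to compound 4 (0.09 log units; that floor lies within the scatter), so compound 4 cannot yet be separated from compound 3.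

Still open, on these data alone, is how far the true value of compound 4 lies past its limit, and with it whether 4H-1,2,4-triazol-4-yl differs from 1H-imidazol-2-yl in this assay at all. Also open, as far as these compounds go, is what an amine or a nitrile at this place would give, and whether any such group would stay close to compound 1 or move towards compound 4.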